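The source may hold more compounds than are shown below. What is called first, only, known or untested is meant among the compounds shown, and "the series" means these compounds.

Compound 1 `Cc1ccc(C(=O)CCc2nnc(Cc3ccccc3)o2)cc1` is the reference point of this small set; in a functional assay on the whole organism (strain Wistar) for inhibition, with Rattus norvegicus as the target, with stated times of 30 min and 2 h, at a dose of 20 mg/kg by the oral route (on this read-out higher numbers stand for more inhibition at the one dose given (going by the name of the read-out) and lower numbers for less inhibition), compound 1 gives 24.7%. Compound 2 `Cc1ccc(C(=O)CCc2nnc(COc3ccccc3)o2)cc1` differs from compound 1 only by phenoxy in place of phenyl on a saturated chain carbon bound to an aromatic carbon, and the step of a number 0.6 percentage points higher from compound 1 to compound 2 (within the scatter) leaves the two compounds indistinguishable at this dose; in this assay compound 2 gives 25.3%. Compound 3 `Cc1ccc(C(=O)CCc2nnc(Cc3ccccc3)o2)c(C)c1` differs from compound 1 by methyl in place of hydrogen on an aromatic carbon, and the step of a number 0.6 percentage points higher from compound 1 to compound 3 (within the scatter) is likewise of no consequence; in this assay compound 3 gives 25.3%, the same number at the digits reported as compound 2 and within the scatter of compound 1.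

Compound 4 `Cc1ccc(C(=O)CCc2nnc(COc3ccccc3)o2)c(C)c1` has not yet been measured. Among the compounds with values here, it differs from compound 3 by phenoxy in place of phenyl on a saturated chain carbon bound to an aromatic carbon, which is the same change as the one made from compound 1 to compound 2, at the same place; the two cores differ by methyl in place of hydrogen on an aromatic carbon. Because the earlier step of a number 0.6 percentage points higher from compound 1 to compound 2 (within the scatter) stayed within the scatter, compound 4 is expected to move only by a number 0.7 percentage points higher from compound 3 to compound 4 (within the scatter). Compound 4 is therefore estimated to give about 26%, with a likely range from 15% to 37%.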

Compound 4, a percentage reported as inhibition, in the whole organism at one dose (the size of the read-out at that dose, not a potency): 27.6%
Compound 4: the middle estimate sits 1.6 percentage points below what was measured; the range from low to high includes it.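

In this assay, phenoxy in place of phenyl on the core carrying the added methyl gives a number 2.3 percentage points higher from compound 3 to compound 4 (within the scatter), and methyl in place of hydrogen on the core carrying phenoxy gives a number 2.3 percentage points higher from compound 2 to compound 4 (within the scatter); this shows that neither change separates its two compounds at this one dose, and it does not show that a change of measurable size carries from one core to another. The phenoxy change gives steps that agree on the two cores, though agreement between steps this small says little about additivity: the same change on two cores in this assay, a number 0.6 percentage points higher (within the scatter) from compound 1 to compound 2 and a number 2.3 percentage points higher (within the scatter) from compound 3 to compound 4, 1.7 percentage points apart, within the scatter of two such steps The methyl change reads the same way, with the same limit on what can be concluded: the same change on two cores in this assay, a number 0.6 percentage points higher (within the scatter) from compound 1 to compound 3 and a number 2.3 percentage points higher (within the scatter) from compound 2 to compound 4, 1.7 percentage points apart, within the scatter of two such steps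

The compounds shown leave open whether any change at these places can move the inhibition beyond the scatter at all. They also leave open what an amine or a carboxylic acid in place of the phenyl, or a longer chain in place of the benzyl, would do on either core.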